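The compounds below may be only part of what the source reports. "The series", "measured", "known", "first", "only" and "open" are said of these compounds alone.

Working notes on the series. All compounds share one amide core carrying two saturated rings on the nitrogen. Compound 1 `CC1CCCCC1N(C(=O)c1cc(C2CC2)on1)C1CCCCC1C` gives in an assay on isolated protein for agonist activity at sphingosine 1-phosphate receptor 4 (Homo sapiens) (a lower number here means that less compound is needed, a higher number that more compound is needed for the effect), only the limit > 50000 nM. Compound 2 `CC1CCCCC1N(C(=O)c1cc(C2CC2)on1)C1CCCCC1` likewise gives only the limit > 50000 nM in this assay. Within the data shown here, the one step between measured compounds, a step that the two limits leave unreadable from compound 1 to compound 2, is unreadable in size for that reason. Compound 3 `O=C(c1cc(-c2ccccc2)on1)N(C1CCCCC1)C1CCCCC1`, with a phenyl on the core, also gives only the limit > 50000 nM in this assay. Where compound 3 stands is therefore known as a limit alone: every value so far sits at the limit of > 50000 nM in this assay, at which 3 of the 3 values shown sit.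

Compound 4 `COc1ccc(-c2cc(C(=O)N(C3CCCCC3)C3CCCCC3)no2)cc1` differs from compound 3 by methoxy in place of hydrogen on an aromatic carbon, para to a large group; cut one bond further out the difference reads phenyl to 4-methoxyphenyl. Among the measured compounds shown here, no measured step bears on this change: the only step touches a saturated ring carbon and is itself unreadable. With compound 3 at a limit, neither direction nor size can be read from the numbers. The expectation is that compound 4 stays at the limit, estimated at 80000 nM. The range expected for compound 4 runs from 20000 nM to 300000 nM. The expected step is a step that the limit leaves unreadable from compound 3 to compound 4, judged as none beyond the scatter.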

Compound 4, half-maximal effective concentration: > 50000 nM
Compound 4: only a limit was reported; the forecaster's own chance of this, stated with the estimate: 85%; the middle value does not contradict the limit.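

In this assay compound 4 gives > 50000 nM, which is a limit. No step can be read from the pair of compound 3 and compound 4, and the series stands as follows: the limit of > 50000 nM in this assay, at which 4 of the 4 values shown sit. The compounds shown leave open which change to the shared core or its rings, if any, would give a measurable value in this assay.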